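This account rests on a few compounds, and the source may have more. Where it says the series, first, only, none or still open, it means among the compounds named here.

Among the compounds with values here, in a functional assay on ACHN cells (Homo sapiens) for inhibition, read by sulforhodamine B assay (on this read-out lower numbers stand for stronger inhibition of growth and higher numbers for weaker inhibition of growth), compound 1 `COc1cccc(CN2CCC=C(CCC(=O)NO)C2=O)c1` gives 7600 nM and stands as the higher of the two numbers known so far. Compound 2 `Cc1ccc(S(=O)(=O)Nc2ccc(CN3CCC=C(CCC(=O)NO)C3=O)cc2)cc1` gives 370 nM and lies lower, beyond the scatter. Compound 3 `Cc1cccc(CN2CCC=C(CCC(=O)NO)C2=O)c1` carries methyl in place of methoxy on an aromatic carbon. Within the data shown here, no measured pair shows this change, so no step beyond the scatter is expected for it in this assay on present evidence. The estimated step is a 1.3-fold lower number from compound 1 to compound 3 (0.10 log units; within the scatter) and remains small. Compound 3 is expected at 6000 nM within an estimated range of 2500 nM to 14000 nM on this read-out.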

Compound 3, concentration for 50% growth inhibition: 4380 nM
Estimate against measurement, compound 3: 1.4-fold (0.14 log units) above; measured number inside the range.
By their numbers in this assay, from the lowest: compound 2; then compounds 3 and 1 (each within the scatter of the next).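

In this assay, within the data shown here, the first pair that differs only at this place reads a 1.7-fold lower number from compound 1 to compound 3 (0.24 log units; within the scatter). Exchanging methoxy for methyl on this aromatic carbon, which removes the oxygen of the methoxy, therefore does not shift the number beyond the scatter. No measurement at hand explains this result. On these data alone, whether an amine or a carboxylic acid on this carbon would move the number beyond the scatter remains open. So does whether methoxy and methyl would read alike on another carbon of the same ring.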